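Series notes: substituent on the nitrogen of compound 3

A few compounds are considered here, and "the series" means these few. Any claim that something is new, unique, unknown or untested is made for them only; others in the source may bear on it.

Measured so far in a functional assay (aorta) for antagonist activity, with Oryctolagus cuniculus as the target; on this read-out higher numbers stand for weaker inhibition and lower numbers for stronger inhibition:
compound 1, `CCCCc1ccc(CNC(C)=O)c(=O)n1Cc1ccc(-c2ccccc2-c2nn[nH]n2)cc1`, gives 3 nM
compound 2, `CCCCc1ccc(CN(Cc2ccccc2)C(C)=O)c(=O)n1Cc1ccc(-c2ccccc2-c2nn[nH]n2)cc1`, gives 1 nM
compound 3, `CCCCc1ccc(CNS(=O)(=O)c2ccc(C)cc2)c(=O)n1Cc1ccc(-c2ccccc2-c2nn[nH]n2)cc1`, gives 9 nM

Compound 3 stands highest of the three numbers in this assay: the step of a 3.0-fold higher number from compound 1 to compound 3 (0.48 log units; beyond the scatter) and the step of a 9.0-fold higher number from compound 2 to compound 3 (0.95 log units; beyond the scatter) are both beyond the scatter, so compound 3 is the weakest of the measured set.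

Compound 4, `CCCCc1ccc(CN(C)S(=O)(=O)c2ccc(C)cc2)c(=O)n1Cc1ccc(-c2ccccc2-c2nn[nH]n2)cc1`, differs from compound 3 by methyl in place of hydrogen on a sulfonamide nitrogen. Within the data shown here, no measured step puts a substituent on a sulfonamide nitrogen. Among the measured compounds shown here, the one step that bears on it is substitution on a nitrogen of the same side chain, a 3.0-fold lower number from compound 1 to compound 2 (0.48 log units; beyond the scatter), where benzyl in place of hydrogen gave a lower number. Methyl is a smaller group and the nitrogen here is of a different kind, so only a small shift downward, if any, is expected, and one that may stay within the scatter.

Compound 4 is therefore expected at 5 nM, with a range from 2 nM to 15 nM, which means an estimated step of a 1.8-fold lower number from compound 3 to compound 4 (0.26 log units; within the scatter).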

Compound 4, half-maximal inhibitory concentration: 8 nM
For compound 4 the middle estimate is 1.6-fold (0.20 log units) below the measured one; measured number inside the range.
By their numbers in this assay, from the lowest: compound 2; then compound 1; then compounds 4 and 3 (each within the scatter of the next).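

In this assay, methyl on the sulfonamide nitrogen leaves no readable difference: a 1.1-fold lower number from compound 3 to compound 4 (0.05 log units; within the scatter) stays within the scatter, unlike the step on the amide-type nitrogen, where benzyl rather than methyl is the entering group. The gap to the acetyl-bearing side chains persists with this nitrogen substituted, since a 2.7-fold higher number from compound 1 to compound 4 (0.43 log units; beyond the scatter) and an 8.0-fold higher number from compound 2 to compound 4 (0.90 log units; beyond the scatter) are both beyond the scatter. No evidence is available that bears on these results.

The compounds shown leave open whether a larger group on the sulfonamide nitrogen, such as benzyl or a longer chain like propyl, would give a step beyond the scatter. They also leave open how a carboxylic acid or an amine at the end of such a chain would read out.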